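The source may hold more compounds than are shown below. What is called first, only, known or untested is meant among the compounds shown, and "the series" means these compounds.

Measured so far:
compound 1 `Nc1cccc2c(-c3cccc(NC(=O)c4ccc(Cl)c(C(F)(F)F)c4)c3)ccnc12` gives 2700 nM in a functional assay on UACC-62 cells (Homo sapiens) for antiproliferative activity, read by sulforhodamine B assay, with a stated time of 48 h; a higher number here means a weaker inhibitor, a lower number a stronger inhibitor
compound 2 `Nc1cccc2c(-c3cccc(NC(=O)c4ccc5c(c4)OCCO5)c3)ccnc12` gives 110 nM in this assay

Of these two numbers, compound 2 holds the lower one; the nearer and only neighbour is compound 1, whose value lies well beyond the scatter above it. Compound 3 `Nc1cccc2c(-c3cccc(NC(=O)c4nccs4)c3)ccnc12` is not yet measured. It differs from compound 2 by a single change: 1,3-thiazol-2-yl in place of 2,3-dihydro-1,4-benzodioxin-6-yl on a carbonyl carbon. Within the data shown here, no measured step informs on such a swap directly; the only comparison available, between compound 1 and compound 2, shows that the group on the carbonyl carbon can move the number a long way. On that basis a step upward, beyond the scatter, is expected a 5.5-fold higher number from compound 2 to compound 3 (0.74 log units; beyond the scatter), though with wide uncertainty. For compound 3 the estimate in this assay is 600 nM, within a range from 150 nM to 2500 nM.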

Compound 3, half-maximal inhibitory concentration: 6000 nM
For compound 3 the middle estimate is 10-fold (1.00 log units) below the measured one, outside the stated range (above it).
By their numbers in this assay, from the lowest: compound 2; then compound 1; then compound 3.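

In this assay the group on the carbonyl carbon proves decisive again: 1,3-thiazol-2-yl in place of 2,3-dihydro-1,4-benzodioxin-6-yl gives a 55-fold higher number from compound 2 to compound 3 (1.74 log units; beyond the scatter) and is a large step beyond the scatter. Here one five-membered aromatic ring with 2 hetero atoms replaces a six-membered aromatic ring of carbon only and its six-membered non-aromatic ring, while the count of hydrogen-bond acceptors stays the same in both groups. Nothing measured on these compounds explains the loss.

The three compounds do not separate the effect of the sulfur-containing ring from that of removing the fused ring. A plain phenyl, a pyridine ring or a furan ring on the same carbonyl carbon would bear on that question.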